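The source may hold more compounds than are shown below. What is called first, only, known or untested is meant among the compounds shown, and "the series" means these compounds.

Working notes on the series, followed in an ADME assay on HEK293-A cells (Homo sapiens) for cytotoxicity, read by MTT assay, with a stated time of 48 h; a lower number here means a stronger inhibitor, a higher number a weaker inhibitor. Compound 1 `CN1CCN(C[C@H]2CN(c3ccc(-n4cc(-c5ccccn5)cn4)c(F)c3)C(=O)O2)CC1` gives 70 ug/mL in this assay and is the only member of the series for which a number rather than a limit is shown. Compound 2 `O=C1O[C@@H](CN2CCC(c3ccc(F)cc3)CC2)CN1c1ccc(-n2cc(-c3ccccn3)cn2)c(F)c1` gives > 400 ug/mL in this assay, which is a limit of the assay and not a number. Compound 2 thus sits at the limit of > 400 ug/mL in this assay, at which 1 of the 2 values shown sits. Among the compounds with values here, no step between two measured compounds that differ in one place is available, so the change from compound 1 to compound 3 has to be judged from the structural change alone. Compound 3 `O=C1CCC(=O)N1C[C@H]1CN(c2ccc(-n3cc(-c4ccccn4)cn3)c(F)c2)C(=O)O1` differs from compound 1 as follows: 2,5-dioxopyrrolidin-1-yl in place of 4-methylpiperazin-1-yl on a saturated chain carbon bound to a saturated ring carbon. For this change the expectation is either no step beyond the scatter of repeated measurement or a step toward weaker inhibition in this assay, and no step beyond the scatter toward stronger inhibition is expected. Compound 3 is expected to give about 150 ug/mL in this assay, within a range from 50 ug/mL to 400 ug/mL. That corresponds to an expected 2.1-fold higher number from compound 1 to compound 3 (0.33 log units; beyond the scatter).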

Compound 3, half-maximal inhibitory concentration: > 400 ug/mL
Compound 3: no number, only a limit; the forecaster's own chance of this, stated with the estimate: 35%; at least 2.6-fold (0.42 log units) between middle value and limit.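

In this assay, 2,5-dioxopyrrolidin-1-yl in place of 4-methylpiperazin-1-yl on a saturated chain carbon bound to a saturated ring carbon gives an at least 5.7-fold higher number from compound 1 to compound 3 (0.75 log units; beyond the scatter), the first step shown at this position and one that lies beyond the scatter. Compound 3 gives > 400 ug/mL, which is a limit of the assay and not a number. The entering and leaving groups have the same heavy-atom, hydrogen-bond donor and hydrogen-bond acceptor counts, so the step does not follow those counts, and its full size cannot be read: the limit of > 400 ug/mL in this assay, at which 2 of the 3 values shown sit.

Within the data shown here, no step between compound 2 and compound 3 can be read, as both values are limits, so the series shows only that compound 1 has a measured number while two other groups at this position do not. On these data alone, whether morpholin-4-yl, a primary amine or a carboxylic acid on the same saturated chain carbon would give a measured number in this assay, and how that number would compare with compound 1, remains open.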